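From Methoxy to Biphenyl on a Shared Ester Core

The compounds below may be only part of what the source reports. "The series", "measured", "known", "first", "only" and "open" are said of these compounds alone.

In an ADME assay on a cell-free system (plasma, Homo sapiens) for metabolic stability, with Plasma (Rattus norvegicus) as the target, read by HPLC, at pH 7.4 (a higher number here means that the compound lasts longer, a lower number that the compound disappears faster), compound 2 `COc1cccc(C(=O)O[C@@H]2CO[C@H]3[C@@H]2OC[C@@H]3OC(=O)c2ccccc2OC(C)=O)c1` gives 0.0142 h. Compound 1 `CC(=O)Oc1ccccc1C(=O)O[C@H]1CO[C@H]2[C@@H]1OC[C@H]2OC(=O)c1ccccc1` gives 0.0107 h in this assay, and the step of a 1.3-fold higher number from compound 1 to compound 2 (0.12 log units; within the scatter) places compound 2 alongside compound 1 rather than apart from it. Compound 3 `CC(=O)Oc1ccccc1C(=O)O[C@H]1CO[C@H]2[C@@H]1OC[C@H]2OC(=O)c1ccc(-c2ccccc2)cc1` differs from compound 2 by 4-phenylphenyl in place of 3-methoxyphenyl on a carbonyl carbon. Among the compounds with values here, the single measured step, a change at the same carbonyl carbon, did not move the half-life beyond the scatter, so the expected step of a 1.1-fold lower number from compound 2 to compound 3 (0.04 log units; within the scatter) is likewise no change beyond the scatter. Compound 3 is therefore estimated at 0.013 h, within a range from 0.006 h to 0.03 h.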

Compound 3, half-life: > 0.333 h
Compound 3 ended at the assay's limit; the forecaster's own chance of this, stated with the estimate: 5%; middle value at least 25-fold (1.40 log units) from the limit.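

Unlike the methoxy step, the change at this carbonyl carbon moves the half-life in this assay well beyond the scatter: 4-phenylphenyl in place of 3-methoxyphenyl gives an at least 23-fold higher number from compound 2 to compound 3 (1.37 log units; beyond the scatter). Phenyl in place of hydrogen on an aromatic carbon likewise gives an at least 31-fold higher number from compound 1 to compound 3 (1.49 log units; beyond the scatter), so this position is not indifferent to what it carries. The value of compound 3, > 0.333 h, is a limit of the assay and not a number: the limit of > 0.333 h in this assay, at which 1 of the 3 values shown sits.

Going by these compounds, how long compound 3 actually lasts stays open. So does whether the second phenyl ring itself matters, or whether an amine or a chlorine in its place would do the same.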